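This account rests on a few compounds, and the source may have more. Where it says the series, first, only, none or still open, it means among the compounds named here.

Working notes on the series. Within the data shown here, in a functional assay on C6 cells (Rattus norvegicus) for cytotoxicity, read by MTT assay, with a stated time of 24 h (on this read-out higher numbers stand for weaker inhibition and lower numbers for stronger inhibition), compound 2 `Cc1nnc(SCC(=O)N/N=c2/scc(-c3ccc(F)cc3)n2-c2ccccc2)s1` gives 27.3 ug/mL, the only number obtained so far; compound 1 `Cc1nnc(SCC(=O)N/N=c2/scc(-c3ccc(C#N)cc3)n2-c2ccccc2)s1`, the nitrile analogue, gives "not determined" (no result reported) in this assay. Compound 2 thus stands alone without comparison. Compound 3 `COc1ccc(-c2cs/c(=N/NC(=O)CSc3nnc(C)s3)n2-c2ccccc2)cc1` is the next entry, carrying (methoxy in place of fluoro on an aromatic carbon). Among the measured compounds shown here, no measured step is available to calibrate this change, so no direction beyond the scatter is expected; the step from a 1.1-fold higher number from compound 2 to compound 3 (0.04 log units; within the scatter) is estimated to stay within the usual scatter. Compound 3 is expected to give about 30 ug/mL in this assay, with a range of 12 ug/mL to 75 ug/mL.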

Compound 3, half-maximal inhibitory concentration: 18.7 ug/mL
Compound 3: middle estimate off by 1.6-fold (0.21 log units), on the high side, within the range that was stated.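

In this assay, among these compounds, the step of a 1.5-fold lower number from compound 2 to compound 3 (0.16 log units; within the scatter) gives the first reading at this position, on an aromatic carbon para to a large group. Methoxy in place of fluoro, a change from 4-fluorophenyl to 4-methoxyphenyl, does not separate the two compounds beyond the usual scatter. Nothing available bears on why the two values fall so close.

On these data alone, what an amine or a carboxylic acid at this position would give remains open. So does whether any group here can move the number beyond the scatter.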